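Working notes: a saturated chain substituent returns in compound 4

This account rests on a few compounds, and the source may have more. Where it says the series, first, only, none or still open, it means among the compounds named here.

Measured in an in vitro functional assay on cells for agonist activity at Bombesin receptor subtype-3 (Homo sapiens), read by luminescence and calcium flux; a lower number here means that less compound is needed, a higher number that more compound is needed for the effect:
compound 1 `O=C(O)c1ccccc1-c1ccc(CCc2ncc(CC3CCC3)[nH]2)cc1`: 588 nM
compound 2 `COc1ccc(Cc2cnc(CCc3ccc(-c4ccccc4C(=O)O)cc3)[nH]2)cc1`: 5360 nM
compound 3 `N#Cc1ccc(Cc2cnc(CCc3ccc(-c4ccccc4C(=O)O)cc3)[nH]2)cc1`: 5890 nM

Compound 3 gives the highest of the three numbers in this assay. Its nearest neighbour is compound 2, and the step between the two aryl-substituted compounds, a 1.1-fold higher number from compound 2 to compound 3 (0.04 log units; within the scatter), lies within the scatter, so no order between them is claimed. The step of a 10-fold higher number from compound 1 to compound 3 (1.00 log units; beyond the scatter) is beyond the scatter, as is a 9.1-fold higher number from compound 1 to compound 2 (0.96 log units; beyond the scatter): both aryl groups on the saturated chain carbon bound to an aromatic carbon gave clearly higher numbers than cyclobutyl at the same place.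

Compound 4 `CC(C)(C)Cc1cnc(CCc2ccc(-c3ccccc3C(=O)O)cc2)[nH]1` differs from compound 3 by tert-butyl in place of 4-cyanophenyl on a saturated chain carbon bound to an aromatic carbon. This is the reverse direction of the two measured steps, aryl replaced by a small saturated group, and tert-butyl is closer in kind to cyclobutyl than to either phenyl. The expectation is therefore a fall in this assay of about the size seen in those steps, landing near compound 1, expected as a 7.4-fold lower number from compound 3 to compound 4 (0.87 log units; beyond the scatter). For compound 4 the estimate is 800 nM, with a range from 300 nM to 2500 nM.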

Compound 4, half-maximal effective concentration: 106 nM
For compound 4 the middle estimate is 7.5-fold (0.88 log units) above the measured one; the measured number lies below the stated range.
By their numbers in this assay, from the lowest: compound 4; then compound 1; then compounds 2 and 3 (each within the scatter of the next).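

In this assay, the aryl groups and tert-butyl on a saturated chain carbon bound to an aromatic carbon lie far apart, as both large steps show (a 56-fold lower number from compound 3 to compound 4 (1.74 log units; beyond the scatter); a 51-fold lower number from compound 2 to compound 4 (1.70 log units; beyond the scatter)). The earlier compounds shown here separated aryl groups from cyclobutyl only, whereas this result shows that the place also distinguishes between two saturated groups (a 5.5-fold lower number from compound 1 to compound 4 (0.74 log units; beyond the scatter)), so cyclobutyl and tert-butyl cannot be treated as interchangeable and compound 4 has the lowest number of the four, with all of its steps beyond the scatter. No measurement at hand bears on the reason for this difference.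

The compounds shown leave open how far the number follows the shape of the saturated group, since neither isopropyl, cyclopentyl nor a longer chain stands among them at this place, and an amine or a hydroxyl on the chain is equally untested here. They also leave open whether the gain seen with tert-butyl holds when the carboxylic acid of the shared core is replaced by a tetrazole or an amide.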